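Fluoro to methyl on the aryl ether: working notes

A few compounds are considered here, and "the series" means these few. Any claim that something is new, unique, unknown or untested is made for them only; others in the source may bear on it.

Compound 1 `CCn1c(=O)c2c(nc(COc3ccc(F)cc3)n2C)n(CC)c1=O` stands lowest of the two numbers in hand. In an assay on brain cells (strain Sprague-Dawley) for displacement of a labelled ligand from adenosine receptor A1 (Rattus norvegicus), read by scintillation counting, with a stated time of 60 min (a lower number here means a stronger inhibitor, a higher number a weaker inhibitor), compound 1 gives 1230 nM. Among the measured compounds shown here, compound 2 `COc1ccc(OCc2nc3c(c(=O)n(C)c(=O)n3C)n2C)cc1` differs from compound 1 in more than one place, so no single step links the two; in this assay compound 2 gives 4670 nM, a higher number that lies beyond the scatter. Compound 3 `CCn1c(=O)c2c(nc(COc3ccc(C)cc3)n2C)n(CC)c1=O` keeps the core of compound 1 and changes only the aryl ether, 4-fluorophenoxy to 4-methylphenoxy: methyl in place of fluoro on an aromatic carbon, para to a large group. For the measured compounds named here, no measured pair shows this same change, so there is no step in hand from which to read its size. The expectation is a step of little size, none beyond the scatter in either direction. Compound 3 is expected to give 1500 nM in this assay, within 500 nM to 4500 nM. The step from compound 1 to compound 3 is estimated at a 1.2-fold higher number from compound 1 to compound 3 (0.09 log units; within the scatter).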

Compound 3, inhibition constant: 1420 nM
Compound 3: middle estimate off by 1.1-fold (0.02 log units), on the high side; the measured number falls inside the stated range.
By their numbers in this assay, from the lowest: compounds 1 and 3 (each within the scatter of the next); then compound 2.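

In this assay, methyl in place of fluoro on an aromatic carbon, para to a large group, gives a 1.2-fold higher number from compound 1 to compound 3 (0.06 log units; within the scatter), so the two groups are not told apart at this position. Among the compounds shown here, this is the first single-place step: compound 1 and compound 2 differ in more than one place, and their values say nothing about this position on its own. No measurement in hand bears on the reason for this result.

Still open, going by these compounds, is whether an amine, a carboxylic acid or a nitrile on this same aromatic carbon would stand apart from fluoro and methyl. The step also leaves open whether the same exchange would read alike on a different core, or with a longer chain in place of the ethyl groups.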